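The compounds below may be only part of what the source reports. "The series", "measured", "known", "first", "only" and "open" are said of these compounds alone.

Compound 2 `Nc1nc(Cl)c2ncn(Cc3ccc(CCl)cc3)c2n1` is one of two compounds tested in a functional assay on SK-OV-3 cells (Homo sapiens) for cytotoxicity, read by sulforhodamine B assay, with a stated time of 48 h; a higher number here means that more compound is tolerated, a lower number that less compound is tolerated; in that assay compound 2 gives 64500 nM, the lower end of the two numbers, while compound 1 `ClCc1ccc(Cn2cnc3c(Cl)ncnc32)cc1` gives 91200 nM. The two differ only by an amino in place of hydrogen on an aromatic carbon, and the step of a 1.4-fold lower number from compound 1 to compound 2 (0.15 log units; within the scatter) lies within the scatter, so adding the amino left the number essentially unchanged. Compound 3 `ClCc1ccc(Cn2cnc3c(Cl)nc(Cl)nc32)cc1` has not yet been measured. It differs from compound 2 by chloro in place of amino on an aromatic carbon. For the measured compounds named here, the only measured step that bears on this change is the one from compound 1 to compound 2 at the same aromatic carbon, and it was small; these numbers give no reason to expect a step beyond the scatter in this assay. Compound 3 is therefore estimated at 70000 nM, with a range from 30000 nM to 160000 nM, which corresponds to an expected step of a 1.1-fold higher number from compound 2 to compound 3 (0.04 log units; within the scatter).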

Compound 3, concentration lethal to 50% of the cells: 66100 nM
The estimate for compound 3 lay 1.1-fold (0.02 log units) above the measured number; the measured number falls inside the stated range.
By their numbers in this assay, from the lowest: compounds 2, 3 and 1 (each within the scatter of the next).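

Chloro in place of amino gives a 1.0-fold higher number from compound 2 to compound 3 (0.01 log units; within the scatter) and chloro in place of hydrogen gives a 1.4-fold lower number from compound 1 to compound 3 (0.14 log units; within the scatter) in this assay at this carbon between two ring nitrogen atoms. Hydrogen, amino and chloro at this carbon therefore cannot be told apart in these three compounds, even though amino counts one hydrogen-bond donor and one hydrogen-bond acceptor and chloro counts neither. Nothing available explains this result.

All three groups are single heavy atoms on the carbon, so the compounds shown leave open whether something larger there, such as a methoxy group, a morpholine ring or a longer chain, would give a step beyond the scatter. They also leave open whether the chloromethyl group shared by all three compounds matters for the number.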